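Sulfo in Place of Ethyl on Compound 2

The compounds below may be only part of what the source reports. "The series", "measured", "known", "first", "only" and "open" are said of these compounds alone.

Measured compounds:
compound 1 `CC(C)(C)c1ccc2nc(N)sc2c1`, in a functional assay on the whole organism with Rattus norvegicus as the target (a lower number here means that less compound is needed, a higher number that more compound is needed for the effect), compound 1 gives 4 mg/kg
compound 2 `CCCCn1c(=N)sc2cc(OC(F)(F)F)ccc21`, in this assay compound 2 gives 10 mg/kg

Of the two measured compounds, compound 2 stands at the higher number; the gap to compound 1 lies beyond the usual scatter, so compound 2 needs more material for the same effect than compound 1 does.

Compound 3 `N=c1sc2cc(OC(F)(F)F)ccc2n1CCS(=O)(=O)O` has not yet been measured. It differs from compound 2 in one place: sulfo in place of ethyl on a saturated chain carbon, two bonds along the chain from an aromatic nitrogen. Read one bond further out, the butyl of compound 2 becomes 2-sulfoethyl in compound 3.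

Within the data shown here, no measured pair shows a step of this kind, so there is no directly comparable change to draw on. The account therefore rests on compound 2 alone. A step in this assay toward a higher number, beyond the scatter, is expected, and the size of that step is uncertain. For compound 3 the expected step is a 3.0-fold higher number from compound 2 to compound 3 (0.48 log units; beyond the scatter). Compound 3 is estimated at 30 mg/kg, within a range from 8 mg/kg to 120 mg/kg.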

Compound 3, dose for half-maximal effect: > 10 mg/kg
Compound 3 gave a limit, no number; the forecaster's own chance of this, stated with the estimate: 25%; the middle value does not contradict the limit.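

In this assay compound 3 gives a limit and not a number: the limit of > 10 mg/kg in this assay, at which 1 of the 3 values shown sits.

Read as a step, the change of butyl to 2-sulfoethyl gives a number no lower from compound 2 to compound 3 (the limit leaves the size open), and this is the first measured change on this chain, which the earlier pair, differing in more than one place, could not speak to. It shows that sulfo in place of ethyl, on a saturated chain carbon, two bonds along the chain from an aromatic nitrogen, brought no move toward a lower dose in this whole-animal read-out, while the size of any move toward a higher number cannot be read.

The compounds shown leave open whether compound 3 lies close to compound 2 or far from it, and this single step gives no pattern for the position. As far as these compounds go, how a carboxylic acid, an amine or a longer chain would read at this place on the chain also remains open.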